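The source may report more compounds than this note shows. Statements on the series, on what has been measured and on what is new or still open speak of the compounds shown alone.

Of the compounds shown here, three sharing one core have been measured in a functional assay on a cell-free system (Platelet, plasma, Homo sapiens) for inhibition; on this read-out lower numbers stand for stronger inhibition and higher numbers for weaker inhibition. Compound 1 `O=C(O)COC1CCN(CCN(C(=O)c2ccc(Cl)cc2)c2ccc(Cl)cc2)CC1` gives 1500 nM. Compound 2 `O=C(O)COC1CCN(CCN(C(=O)c2ccc(C(F)(F)F)cc2)c2ccc(Cl)cc2)CC1` gives > 10000 nM, which is a limit of the assay and not a number. Compound 3 `O=C(O)COC1CCN(CCN(C(=O)c2cccc(F)c2)c2ccc(Cl)cc2)CC1` gives 340 nM, the lower of the two values that are actual numbers, and the step of a 4.4-fold lower number from compound 1 to compound 3 (0.64 log units; beyond the scatter) lies beyond the scatter.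

Compound 4 `O=C(O)COC1CCN(CCN(C(=O)c2cccc(C(F)(F)F)c2)c2ccc(Cl)cc2)CC1` differs from compound 3 at a single place, with trifluoromethyl in place of fluoro on an aromatic carbon, meta to a large group: trifluoromethyl in place of fluoro on an aromatic carbon. Going by the values given here, the closest precedent is the step of an at least 6.6-fold higher number from compound 1 to compound 2 (0.82 log units; beyond the scatter), where trifluoromethyl also enters on an aromatic carbon. There it replaces chloro rather than fluoro, and it gives a 4-(trifluoromethyl)phenyl rather than a 3-(trifluoromethyl)phenyl, so the parallel is only partial. The step of an at least 29-fold lower number from compound 2 to compound 3 (1.46 log units; beyond the scatter) shows how far the number can move with this aromatic group, though it changes more than the one substituent. On this single precedent, a move towards weaker inhibition is expected, of modest size and beyond the scatter. The expected change is estimated as a 3.5-fold higher number from compound 3 to compound 4 (0.55 log units; beyond the scatter). For compound 4 the estimated value is 1200 nM, with an expected range of 350 nM to 6000 nM.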

Compound 4, half-maximal inhibitory concentration: > 10000 nM
Compound 4: only a limit was reported; the forecaster's own chance of this, stated with the estimate: 15%; middle value at least 8.3-fold (0.92 log units) away from the limit.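

Trifluoromethyl in place of fluoro gives an at least 29-fold higher number from compound 3 to compound 4 (1.46 log units; beyond the scatter) in this assay, so the penalty seen earlier with 4-(trifluoromethyl)phenyl, where trifluoromethyl replaced chloro, also appears with 3-(trifluoromethyl)phenyl, where it replaces fluoro. The 3-fluorophenyl of compound 3 thus gives way at this single place to a group that also falls short of the 4-chlorophenyl of compound 1, as an at least 6.6-fold higher number from compound 1 to compound 4 (0.82 log units; beyond the scatter) shows. The step between compound 2 and compound 4 cannot be read, and the two readable steps give only a minimum size, because compound 2 and compound 4 both stand at a limit of the assay rather than at a number: the limit of > 10000 nM in this assay, at which 2 of the 4 values shown sit.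

Going by these compounds, what remains open is how the number behaves with methyl or methoxy in place of fluoro on the same aromatic carbon, which would show whether anything beyond fluoro is accepted there. Also open, on these data alone, is how far compound 2 and compound 4 lie from each other, and so whether moving trifluoromethyl around this aromatic ring matters at all in this assay.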